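Taking the chloro off compound 2: an expectation

This account rests on a few compounds, and the source may have more. Where it says the series, first, only, none or still open, it means among the compounds named here.

Compound 1 `Clc1ccc(OCC2=NCCO2)cc1`: 30.3%
Compound 2 `Cc1cc(OCC2=NCCO2)ccc1Cl`: 22.2%

Both compounds were read in a functional assay on the whole organism for inhibition, with Rattus norvegicus as the target, read by paw edema, with a stated time of 30 min, at a dose of 20 mg/kg by the oral route; on this read-out higher numbers stand for a stronger effect at the one dose given and lower numbers for a weaker effect. Compound 2 holds the smaller of the two numbers shown, yet the gap a number 8.1 percentage points lower from compound 1 to compound 2 (within the scatter) lies within the scatter, so no ranking follows. Compound 3 `Cc1cccc(OCC2=NCCO2)c1` differs from compound 2 by hydrogen in place of chloro on an aromatic carbon. Among the compounds with values here, no measured step touches the chloro group; the single step known concerns a methyl and stayed within the scatter. Accordingly the change is expected to bring no step beyond the scatter, a number 2.2 percentage points lower from compound 2 to compound 3 (within the scatter). Compound 3 is therefore estimated at 20%, within a range of 5% to 36%.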

Compound 3, a percentage reported as inhibition, in the whole organism at one dose (the size of the read-out at that dose, not a potency): 16.6%
Compound 3: the middle estimate sits 3.4 percentage points above what was measured; the range from low to high includes it.
By their numbers in this assay, from the lowest: compounds 3, 2 and 1 (each within the scatter of the next, the first and the last beyond it).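

In this assay, within the data shown here, hydrogen in place of chloro on the aromatic carbon ortho to a methyl group gives a number 5.6 percentage points lower from compound 2 to compound 3 (within the scatter), the first reading of any change at this place. At the one dose given, removing the chloro from compound 2 therefore brings no step beyond the scatter, so the data do not show that this chlorine matters to the read-out. Going by these compounds, whether an amine, a carboxylic acid or a longer chain on this aromatic carbon would bring a step beyond the scatter remains open. No evidence to hand bears on the size of this step.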